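Replacing Amino by Dimethylamino in Compound 1

A few compounds are considered here, and "the series" means these few. Any claim that something is new, unique, unknown or untested is made for them only; others in the source may bear on it.

Measured so far:
Compound 1, `Cc1nc2c(OCc3ccccc3)cccn2c1N`: 99%
Compound 2, `Cc1nc2c(OCc3ccsc3)cccn2c1N`: 52%

Both compounds were tested in a functional assay on the whole organism with Rattus norvegicus as the target, at a dose of 40 mg/kg by the intraperitoneal route; on this read-out lower numbers stand for less inhibition and higher numbers for more inhibition at the one dose given (going by the name of the read-out). Compound 1 gives the highest of the two numbers, and the nearest one, compound 2, lies a number 47 percentage points lower from compound 1 to compound 2 (beyond the scatter), a change that alters the group on the saturated chain carbon bound to the oxygen, not the amino group.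

Compound 3, `Cc1nc2c(OCc3ccccc3)cccn2c1N(C)C`, has not been measured. It differs from compound 1 by dimethylamino in place of amino on an aromatic carbon. For the measured compounds named here, no measured step touches this position: the only measured step, from compound 1 to compound 2, concerns a different part of the molecule, so it says nothing about what swapping amino for dimethylamino does. The expectation therefore rests on compound 1 alone, whose value of 99% leaves little room upward, so any change beyond the scatter can only be a fall.

Compound 3 is expected to give about 80%, within a range from 45% to 99%. This estimate means a step of a number 19 percentage points lower from compound 1 to compound 3 (beyond the scatter), which is expected to be a modest decrease.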

Compound 3, a percentage reported as inhibition, in the whole organism at one dose (the size of the read-out at that dose, not a potency): 76%
Beside the measured number, compound 3's estimate is 4 percentage points above it, within the range that was stated.
By their numbers in this assay, from the lowest: compound 2; then compound 3; then compound 1.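

For the compounds shown here, until now the amino group had stayed fixed, so this is the first view of this position in this assay: dimethylamino in place of amino on the aromatic carbon gives a number 23 percentage points lower from compound 1 to compound 3 (beyond the scatter). The position therefore responds to the change, but the amino group is not essential for a sizeable read-out at this dose: amino has 1 hydrogen-bond donor and dimethylamino has 0 hydrogen-bond donors, yet compound 3 still gives 76%, with less inhibition than compound 1 at the same dose. No measured information explains the fall, and this single step cannot separate the loss of the donor from the arrival of the extra carbon atoms.

The compounds shown leave open how methylamino, which keeps a hydrogen on the nitrogen and adds only one methyl group, or an acetamide would behave at this position. They also leave open whether dimethylamino has a similar effect when thiophen-3-yl stands in place of phenyl on the chain attached to the oxygen.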